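A few compounds are considered here, and "the series" means these few. Any claim that something is new, unique, unknown or untested is made for them only; others in the source may bear on it.

The measured compounds:

Compound 1, `COc1cccc(/C=C2\CCc3cc(OC)c(OC)cc3C2=O)c1`: 5000 nM
Compound 2, `COc1ccc(/C=C2\CCc3cc(OC)c(OC)cc3C2=O)cc1`: > 50000 nM
Compound 3, `COc1cc2c(cc1OC)C(=O)/C(=C/c1cccc(OC)c1OC)CC2`: > 50000 nM

In a functional assay on Jurkat cells (Homo sapiens) for antiproliferative activity, read by MTT assay (a lower number here means a stronger inhibitor, a higher number a weaker inhibitor), compound 1 gives 5000 nM. For compound 2 the value > 50000 nM is a limit of the assay, not a number. For compound 3 the value > 50000 nM is likewise a limit. The change 4-methoxyphenyl in place of 3-methoxyphenyl on a double-bonded chain carbon bound to a double-bonded ring carbon gives an at least 10-fold higher number from compound 1 to compound 2 (1.00 log units; beyond the scatter). The change methoxy in place of hydrogen on an aromatic carbon gives an at least 10-fold higher number from compound 1 to compound 3 (1.00 log units; beyond the scatter). Two of the three values sit at the limit of > 50000 nM in this assay, at which 2 of the 3 values shown sit.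

Compound 4, `COc1ccc(/C=C2\CCc3cc(OC)c(OC)cc3C2=O)c(OC)c1`, is not yet measured in this assay. It differs from compound 2 by methoxy in place of hydrogen on an aromatic carbon. Among the compounds with values here, this is the same kind of change as the one from compound 1 to compound 3, but the place is not the same: in compound 3 the entering methoxy is ortho to a methoxy group, in compound 4 it is meta to a methoxy group. Since compound 2 already stands at a limit, compound 4 is expected to stay at a limit, a step that the limit leaves unreadable from compound 2 to compound 4, resting on the loss seen in an at least 10-fold higher number from compound 1 to compound 3 (1.00 log units; beyond the scatter). The estimate for compound 4 is 100000 nM, between 30000 nM and 500000 nM.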

Compound 4, half-maximal inhibitory concentration: > 50000 nM
Compound 4 gave a limit, no number; the forecaster's own chance of this, stated with the estimate: 80%; the middle value does not contradict the limit.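

In this assay compound 4 gives > 50000 nM, which is a limit of the assay and not a number. Compound 2 also stands at a limit, so no step can be read from compound 2 to compound 4: the limit of > 50000 nM in this assay, at which 3 of the 4 values shown sit. The compounds shown leave open whether methoxy in place of hydrogen on an aromatic carbon changes the activity of compound 2 at all.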